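Methoxy in place of trifluoromethyl on an ethyl ester

A few compounds are considered here, and "the series" means these few. Any claim that something is new, unique, unknown or untested is made for them only; others in the source may bear on it.

Of the compounds shown here, three built on a shared core have been tested in a functional assay on the whole organism (strain Sprague-Dawley) for inhibition, with Rattus norvegicus as the target, with a stated time of 10 min (a higher number here means that more compound is needed for the effect, a lower number that less compound is needed), and none has yet given a number. Compound 3 `CCOC(=O)c1cnc(-c2ccc(C(F)(F)F)cc2)[nH]c1=O`, an ethyl ester, gives > 5 mg/kg, which is a limit of the assay. Compound 2 `CCOC(=O)c1cnc(-c2ccc(Cl)cc2)[nH]c1=O`, also an ethyl ester, gives > 30 mg/kg, likewise a limit. Compound 1 `COc1ccc(-c2ncc(C(=O)O)c(=O)[nH]2)cc1`, a free acid, gives > 5 mg/kg, again a limit. Compound 3 therefore has no measured dose, only a limit shared with compound 1.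

Compound 4 `CCOC(=O)c1cnc(-c2ccc(OC)cc2)[nH]c1=O` keeps the ester of compound 3 and makes one change, methoxy in place of trifluoromethyl on an aromatic carbon, para to a large group: methoxy in place of trifluoromethyl on an aromatic carbon. For the measured compounds named here, the only measured step at this place is a step that the two limits leave unreadable from compound 2 to compound 3, and it offers no size to carry over. Compound 1 also carries methoxy, but it offers only a limit and differs at the acid. The data therefore support no expected direction in this assay, and no step beyond the scatter is expected. The expected step is a step that the limit leaves unreadable from compound 3 to compound 4. For compound 4 the estimate is 15 mg/kg, within an expected range from 5 mg/kg to 50 mg/kg, and another limit would not be unexpected.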

Compound 4, dose for 50% inhibition: 30 mg/kg
The estimate for compound 4 lay 2.0-fold (0.30 log units) below the measured number; the range from low to high includes it.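

In this assay compound 4 gives 30 mg/kg, the first actual number in the series, so an ethyl ester with methoxy on an aromatic carbon, para to a large group, is shown to reach a measured dose, which none of the earlier compounds did. Methoxy in place of chloro gives a number no higher from compound 2 to compound 4 (the limit leaves the size open), but the size of that step cannot be read, and neither can the steps from compound 3 and from compound 1 to compound 4, so no change at this position has a known size yet. The series has gained one measured dose, while the other compounds remain limits of the assay: the limit of > 5 mg/kg in this assay, at which 2 of the 4 values shown sit.

The compounds shown leave open whether a measured dose at this place is particular to methoxy or would also appear with an amine or a nitrile on the same aromatic carbon. They also leave open how the dose would respond to a longer chain in place of ethyl on the ester, since the only other form of that end of the molecule, in compound 1, gives a limit.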